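The source may report more compounds than this note shows. Statements on the series, on what has been measured and on what is new or still open speak of the compounds shown alone.

Working notes on the series built on the core of compound 1 `COC1=C(C)C(=O)/C(=C(O)/C=C/c2ccc(Br)cc2)C(=O)C1(C)C`, read in a functional assay on A549 cells (Homo sapiens) for cytotoxicity; on this read-out higher numbers stand for an effect only at larger amounts of compound and lower numbers for an effect already at smaller amounts. Compound 1 gives 1.4 ug/mL, compound 2 `COC1=C(C)C(=O)/C(=C(O)/C=C/c2ccc(F)cc2)C(=O)C1(C)C` gives 3.3 ug/mL and compound 3 `COC1=C(C)C(=O)/C(=C(O)/C=C/c2ccc(C)cc2)C(=O)C1(C)C` gives 4.3 ug/mL. Compound 3 stands level with compound 2 at the upper end of these numbers, since a 1.3-fold higher number from compound 2 to compound 3 (0.11 log units; within the scatter) stays within the scatter, while a 3.1-fold higher number from compound 1 to compound 3 (0.49 log units; beyond the scatter) lies beyond it.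

The next structure is compound 4 `COC1=C(C)C(=O)/C(=C(O)/C=C/c2cc(C)cc(C)c2)C(=O)C1(C)C`: 3,5-dimethylphenyl in place of 4-methylphenyl on a double-bonded chain carbon bound to a double-bonded chain carbon. In words, 3,5-dimethylphenyl comes in place of 4-methylphenyl on a double-bonded chain carbon bound to a double-bonded chain carbon.

Among the compounds with values here, no measured step moves a methyl or adds a second one, so the evidence is indirect. The closest step, methyl in place of fluoro, is a 1.3-fold higher number from compound 2 to compound 3 (0.11 log units; within the scatter). The two bromo replacements are modest: a 2.4-fold higher number from compound 1 to compound 2 (0.37 log units; beyond the scatter) and a 3.1-fold higher number from compound 1 to compound 3 (0.49 log units; beyond the scatter). Within the data shown here, no large step is therefore expected, and no clear direction. The expected step is a 1.0-fold higher number from compound 3 to compound 4 (0.02 log units; within the scatter), an estimate within the scatter. For compound 4 the estimated value is 4.5 ug/mL, with an expected range of 2.2 ug/mL to 9 ug/mL.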

Compound 4, concentration for half-maximal effect: 4.3 ug/mL
Beside the measured number, compound 4's estimate is 1.0-fold (0.02 log units) above it; the range from low to high includes it.
By their numbers in this assay, from the lowest: compound 1; then compounds 2, 3 and 4 (each within the scatter of the next).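

In this assay, 3,5-dimethylphenyl in place of 4-methylphenyl on a double-bonded chain carbon bound to a double-bonded chain carbon gives no change at the digits printed from compound 3 to compound 4 (within the scatter), so this place accepts a second methyl and a changed methyl arrangement without a reading beyond the scatter. The comparison with the halogen groups reads a 1.3-fold higher number from compound 2 to compound 4 (0.11 log units; within the scatter) and a 3.1-fold higher number from compound 1 to compound 4 (0.49 log units; beyond the scatter), so the 3,5-dimethylphenyl group joins the 4-fluorophenyl and 4-methylphenyl groups, while the lowest number stays with compound 1. No supporting measurement bears on the reason for these readings.

Compound 4 differs from compound 3 in both methyl count and arrangement, so the two changes remain unseparated. On these data alone, whether a 3,5-dibromophenyl group would keep the lower number of compound 1, or how an amine or a carboxylic acid on the aromatic ring would read, stays open.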